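The compounds below may be only part of what the source reports. "The series", "measured", "known", "first", "only" and "open" are said of these compounds alone.

Measured compounds:
- compound 1, `O=C1c2sccc2N(Cc2ccccc2Br)S(=O)(=O)N1Cc1ccccc1`: > 270000 nM
- compound 2, `N#Cc1ccccc1CN1c2ccsc2C(=O)N(Cc2ccccc2)S1(=O)=O`: > 305000 nM
- compound 3, `O=C1c2sccc2N(Cc2ccc(Cl)cc2)S(=O)(=O)N1Cc1ccccc1`: 8200 nM

In an ADME assay on MT4 cells (Homo sapiens) for cytotoxicity, read by MTT assay, with a stated time of 4 days (a lower number here means that less compound is tolerated, a higher number that more compound is tolerated), compound 1 gives > 270000 nM, which is a limit of the assay and not a number. Compound 2 likewise gives > 305000 nM, also a limit. Compound 3 is the only one of the three with a measured number, and the two steps that lead to it are both large: an at least 32-fold lower number from compound 1 to compound 3 (1.51 log units; beyond the scatter) and an at least 37-fold lower number from compound 2 to compound 3 (1.57 log units; beyond the scatter). Both steps put a 4-chlorophenyl in place of another ring on a saturated chain carbon bound to a sulfonamide nitrogen in a ring, and both lower the tolerated concentration.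

Compound 4, `CN1c2ccsc2C(=O)N(Cc2ccccc2)S1(=O)=O`, has not yet been measured in this assay. It differs from compound 3 by hydrogen in place of 4-chlorophenyl on a saturated chain carbon bound to a sulfonamide nitrogen in a ring. Since the two large steps toward compound 3 both brought in the 4-chlorophenyl that now leaves, a step back upward is expected from compound 3 to compound 4, about a 12-fold higher number from compound 3 to compound 4 (1.09 log units; beyond the scatter), with a fair chance that only a limit is reported. Compound 4 is therefore estimated at 100000 nM, within 20000 nM to 300000 nM.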

Compound 4, half-maximal cytotoxic concentration: 202000 nM
Beside the measured number, compound 4's estimate is 2.0-fold (0.31 log units) below it; the range from low to high includes it.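

In this assay, a 25-fold higher number from compound 3 to compound 4 (1.39 log units; beyond the scatter), so with 4-chlorobenzyl cut back to methyl, the shared core is tolerated at a far higher concentration. Against the other two groups at this position, the picture is different: an at least 1.5-fold lower number from compound 2 to compound 4 (0.17 log units; that floor lies within the scatter), and an at least 1.3-fold lower number from compound 1 to compound 4 (0.12 log units; that floor lies within the scatter). Those two steps rest on limits of the assay and not on numbers, so they do not set compound 4 apart from compound 1 or compound 2, and among these four compounds only compound 3, with its 4-chlorobenzyl, stands clearly lower.

As far as these compounds go, it remains open whether the lower number follows the chlorine itself or the 4-chlorobenzyl group as a whole. A plain benzyl, a longer chain such as butyl, or a chain ending in an amine at this position would help to separate these readings.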